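Vinyl for Ethyl on a Thioamide TRPV1 Antagonist Scaffold

The source may hold more compounds than are shown below. What is called first, only, known or untested is meant among the compounds shown, and "the series" means these compounds.

Measured compounds:
compound 1, `CC(C)(C)c1ccc(CCC(=S)NCc2ccc(NS(C)(=O)=O)c(Cl)c2)cc1`, 96 nM
compound 2, `CCc1cc(CNC(=S)CCc2ccc(C(C)(C)C)cc2)ccc1NS(C)(=O)=O`, 240 nM

In a functional assay for antagonist activity at transient receptor potential cation channel subfamily V member 1 (Rattus norvegicus) (a higher number here means a weaker inhibitor, a lower number a stronger inhibitor), compound 1 gives 96 nM, and compound 2 gives 240 nM. For the measured compounds named here, compound 2 therefore stands at the higher of the two numbers, with compound 1 its only neighbour, and the single measured step is a 2.5-fold higher number from compound 1 to compound 2 (0.40 log units; beyond the scatter), which swaps a chloro for an ethyl on the aromatic carbon ortho to the methanesulfonamido group.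

Compound 3, `C=Cc1cc(CNC(=S)CCc2ccc(C(C)(C)C)cc2)ccc1NS(C)(=O)=O`, is not yet measured. It differs from compound 2 by vinyl in place of ethyl on an aromatic carbon. Going by the values given here, no measured step covers this exchange of two carbon groups of equal heavy-atom count at the same aromatic carbon; the only step that bears on that position at all, from compound 1 to compound 2, was modest. The group that leaves and the one that enters are the same size, so the expected step of a 1.1-fold lower number from compound 2 to compound 3 (0.04 log units; within the scatter) is one that does not go beyond the scatter, with no preferred direction. Compound 3 is thus expected to give 220 nM in this assay, in a range from 90 nM to 550 nM.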

Compound 3, half-maximal inhibitory concentration: 61 nM
Estimate against measurement, compound 3: 3.6-fold (0.56 log units) above; the measured number lies below the stated range.
By their numbers in this assay, from the lowest: compounds 3 and 1 (each within the scatter of the next); then compound 2.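

In this assay the aromatic carbon ortho to a methanesulfonamido group responds to more than the heavy-atom count of its substituent: ethyl and vinyl have the same count, yet the exchange gives a 3.9-fold lower number from compound 2 to compound 3 (0.59 log units; beyond the scatter) on this otherwise unchanged structure. The one counted difference between the two groups is the double bond outside aromatic rings, and the exchange of chloro for vinyl gives a 1.6-fold lower number from compound 1 to compound 3 (0.20 log units; within the scatter) in the same assay, so compound 3 and compound 1 cannot be separated, and among these three compounds ethyl alone stands apart. Nothing available gives a measured property that would account for the difference between ethyl and vinyl at this carbon.

The compounds shown leave open whether the double bond itself matters or whether an ethynyl group, a cyclopropyl group or a methyl group at this carbon would give a similar number. They also leave open whether the exchange of ethyl for vinyl would give a step of similar size with an amide in place of the thioamide, or with a trifluoromethyl group in place of the tert-butyl group.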